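A few compounds are considered here, and "the series" means these few. Any claim that something is new, unique, unknown or untested is made for them only; others in the source may bear on it.

The series turns on a shared core carrying a fluorinated bicyclic aryl group and an isopropyl-bearing chain, with a five-membered heterocycle at the end of that chain. Compound 1 `C/C(=C1/OC(=O)NC1=O)C(c1ccc(-c2ccc3cccc(F)c3c2)[nH]c1=O)C(C)C` and compound 2 `CC(C)[C@@H](c1ccc(-c2ccc3cccc(F)c3c2)[nH]c1=O)[C@@H]1OC(=O)NC1=O` have been measured in a physicochemical assay for solubility, in phosphate buffer, measured as kinetic solubility; on this read-out higher numbers stand for higher solubility and lower numbers for lower solubility. In this assay compound 1 gives 17200 nM, while compound 2 gives 27400 nM. For the measured compounds named here, these two numbers sit within the usual scatter of each other, so compound 1 cannot be set apart from compound 2 on solubility, and no step between measured compounds has been worked out.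

Compound 3 `CC(C)C(/C=C1/C(=O)NC(=O)N1C)c1ccc(-c2ccc3cccc(F)c3c2)[nH]c1=O` has not yet been measured. It differs from compound 1 by a single exchange: a group of 9 heavy atoms (5 carbon, 2 nitrogen, 2 oxygen; one five-membered non-aromatic ring with 2 hetero atoms) in place of a group of 9 heavy atoms (5 carbon, 1 nitrogen, 3 oxygen; one five-membered non-aromatic ring with 2 hetero atoms), on a saturated chain carbon bound to an aromatic carbon and a saturated chain carbon. The ring that leaves carries one more oxygen and one more hydrogen-bond acceptor than the ring that enters, which instead carries a second nitrogen.

Since only two measured points exist and they agree within the scatter, the step from compound 1 to compound 3 is expected to be small and, if anything, downward, a 1.4-fold lower number from compound 1 to compound 3 (0.16 log units; within the scatter). Compound 3 is therefore estimated at 12000 nM, with a range from 5000 nM to 30000 nM.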

Compound 3, solubility: 34800 nM
Compound 3: middle estimate off by 2.9-fold (0.46 log units), on the low side; measured number outside the range, above it.
By their numbers in this assay, from the lowest: compounds 1, 2 and 3 (each within the scatter of the next, the first and the last beyond it).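

For the compounds shown here, at the place on a saturated chain carbon bound to an aromatic carbon and a saturated chain carbon, the exchange of one five-membered non-aromatic ring for another gives the first readable step in this assay (a 2.0-fold higher number from compound 1 to compound 3 (0.31 log units; beyond the scatter)), which is modest. The two groups match in heavy atoms, carbon count, hydrogen-bond donors and double bonds outside aromatic rings, while the 3 oxygen and 1 nitrogen of the leaving group become 2 oxygen and 2 nitrogen and its 3 hydrogen-bond acceptors become 2, so this position shows a number beyond the scatter even for an exchange that leaves so much of the group's count unchanged. No supporting measurement bears on the result, and which feature of the exchange accounts for the step stays unassigned.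

The compounds shown leave open whether this step is specific to the entering ring or would also appear with a different group at the same place, such as an amine, a carboxylic acid or a longer chain. With one step in hand, they also leave open whether it would hold on any core other than the shared core of these compounds.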